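The source may hold more compounds than are shown below. What is called first, only, known or untested is meant among the compounds shown, and "the series" means these compounds.

The starting point is compound 1 `CC(C)(C)c1conc1N1C(=O)CSC1c1cccc(C(=O)NCCCCc2ccccc2)c1`. In a functional assay on HOS-TE85 cells (Homo sapiens) for inhibition, read by CCK-8 assay, with a stated time of 72 h (on this read-out lower numbers stand for stronger inhibition and higher numbers for weaker inhibition), compound 1 gives > 1000 nM, which is a limit of the assay rather than a number. Compound 1 thus stands at the limit of > 1000 nM in this assay, at which 1 of the 2 values shown sits. The other measured compound, compound 2 `CC1SC(c2cccc(C(=O)NCCCCc3ccc(Cl)cc3)c2)N(c2cccc(C3CC3)c2)C1=O`, gives 932 nM in this assay. Compound 3 `O=C(NCCCCc1ccccc1)c1cccc(C2SCC(=O)N2c2cccc(F)c2)c1` has not yet been measured. It differs from compound 1 by a group of 7 heavy atoms (6 carbon, 1 fluorine; one six-membered aromatic ring of carbon only) in place of a group of 9 heavy atoms (7 carbon, 1 nitrogen, 1 oxygen; one five-membered aromatic ring with 2 hetero atoms), on an amide-type nitrogen in a ring; the incoming group sits on an amide-type nitrogen in a ring of a five-membered non-aromatic ring with 1 nitrogen and 1 sulfur, two ring bonds from the ring sulfur. Within the data shown here, no step between measured compounds is available, and compound 1 offers only a limit, so the step that the limit leaves unreadable from compound 1 to compound 3 is expected to be small, with no direction beyond the scatter. The expectation leans on compound 2, which gives 932 nM. Compound 3 is therefore estimated at 1200 nM, within 400 nM to 4000 nM.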

Compound 3, half-maximal inhibitory concentration: 32.4 nM
Compound 3: middle estimate off by 37-fold (1.57 log units), on the high side; measured number outside the range, below it.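

In this assay compound 1 gives > 1000 nM, which is a limit of the assay and not a number. With 3-fluorophenyl in place of the group holding the five-membered aromatic ring, on the amide-type nitrogen in a ring, the data show an at least 30-fold lower number from compound 1 to compound 3 (1.48 log units; beyond the scatter), the first readable sign that the group at this place has a large bearing on the read-out. This step is a lower bound, and its full size cannot be read: the limit of > 1000 nM in this assay, at which 1 of the 3 values shown sits.

The compounds shown do not separate the six-membered carbon ring from its fluorine, so how a plain phenyl or a 3-chlorophenyl would read at this place stays open. As far as these compounds go, whether the same exchange carries over to the core of compound 2 also remains open.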